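A Trimethylpiperazine in Place of an Oxetanyl Piperazine

This account rests on a few compounds, and the source may have more. Where it says the series, first, only, none or still open, it means among the compounds named here.

Measured so far in an ADME assay on microsomes from liver (Mus musculus) for metabolic stability, read by LC-MS, with a stated time of 10 min; a higher number here means that more of the compound is left, a lower number that less of the compound is left:
- Compound 1 `c1cnc2c(c1)CCC[C@@H]2N(CC1CC1)C[C@H]1Cc2c(cccc2N2CCNCC2)CN1`: 88.3%
- Compound 2 `CN(C[C@H]1Cc2c(cccc2N2CCN(C3COC3)CC2)CN1)[C@H]1CCCc2cccnc21`: 50.8%

Of the two measured compounds, compound 2 stands lower at 50.8%, and the gap to compound 1 at 88.3% lies beyond the scatter. These two compounds differ in more than one place, so their gap cannot be assigned to any single group.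

The next compound, compound 3 `C[C@@H]1CN(c2cccc3c2C[C@H](CN(C)[C@H]2CCCc4cccnc42)NC3)C[C@H](C)N1C`, keeps the core of compound 2 and changes one substituent. A 3,4,5-trimethylpiperazin-1-yl group takes the place of the 4-(oxetan-3-yl)piperazin-1-yl group on an aromatic carbon (3,4,5-trimethylpiperazin-1-yl in place of 4-(oxetan-3-yl)piperazin-1-yl on an aromatic carbon). The new group also brings two defined stereocentres.

Going by the values given here, no measured pair shows this change alone, so the expectation for this assay is a loose one and starts from compound 2 at 50.8%. A small downward move that stays within the scatter is expected, an estimated a number 6.8 percentage points lower from compound 2 to compound 3 (within the scatter). For compound 3 the estimated value is 44%, with an expected range from 22% to 68%.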

Compound 3, percent of the compound remaining: 39.6%
Compound 3: middle estimate off by 4.4 percentage points, on the high side; low and high end bracket the measured number.
By their numbers in this assay, from the lowest: compound 3; then compound 2; then compound 1.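

In this assay, going by these compounds alone, the replacement of 4-(oxetan-3-yl)piperazin-1-yl by 3,4,5-trimethylpiperazin-1-yl on an aromatic carbon gives the first step in this set that differs in one place only, a number 11.2 percentage points lower from compound 2 to compound 3 (beyond the scatter), which shows that the substituent at this position can shift the percent remaining on the shared core by more than the usual scatter. The entering group differs from the leaving one in several ways at once: it has no four-membered ring and no oxygen, and it carries 2 defined stereocentres, so this single step cannot assign the shift to any one of these features. Nothing at hand gives a reason for the step.

The compounds shown leave open how a morpholine, or a 4-methylpiperazin-1-yl group with no further methyl groups on the ring, would read at this aromatic carbon, and so which part of the trimethylpiperazine goes with the shift. They also leave open whether the step would keep its size with a cyclopropylmethyl group on the amine in place of the methyl group.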